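The source may hold more compounds than are shown below. What is called first, only, known or untested is meant among the compounds shown, and "the series" means these compounds.

Measured compounds in a physicochemical assay for lipophilicity, at pH 7.4; on this read-out lower numbers stand for lower lipophilicity and higher numbers for higher lipophilicity:
- compound 1, `Cc1c2c(nn1-c1nnc(-c3ccc(OC(C)C)c(C#N)c3)s1)CCN(CCC(=O)O)C2`, gives 2.76
- compound 2, `CC(C)Oc1ccc(-c2nnc(-c3ccccc3)s2)cc1Cl`, gives 8.65
- compound 3, `CC(C)Oc1ccc(-c2nnc(-n3cc4c(n3)CCN(CCCC(=O)O)C4)s2)cc1C#N`, gives 2.87

Among these three, compound 2 has the highest number in this assay, well beyond the scatter above compound 3 and compound 1, which lie far below it and close to each other. Compounds 1 and 3 both carry an acid group on a chain, while compound 2 has none; this is only what the three values show, not a rule.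

The step under consideration goes from compound 2 to compound 4, `CC(C)Oc1ccc(-c2nnc(-c3ccno3)s2)cc1Cl`, which has not yet been measured in this assay. The change is this: 1,2-oxazol-5-yl in place of phenyl on an aromatic carbon. The new group brings two hydrogen-bond acceptors in place of a ring of carbon only.

Within the data shown here, no step between two measured compounds sets this change apart, so the expectation rests on the shift of compound 2 alone. A move from a carbon-only ring to one holding a nitrogen and an oxygen is expected to lower the number in this assay by a moderate amount, beyond the scatter: the step from compound 2 to compound 4 is estimated as a number 1.35 log units lower from compound 2 to compound 4 (beyond the scatter). Compound 4 is therefore expected to give about 7.3, within a range from 6.3 to 8.3.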

Compound 4, distribution coefficient: 6.93
The estimate for compound 4 lay 0.37 log units above the measured number; low and high end bracket the measured number.
By their numbers in this assay, from the lowest: compounds 1 and 3 (each within the scatter of the next); then compound 4; then compound 2.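

In this assay, 1,2-oxazol-5-yl in place of phenyl gives a number 1.72 log units lower from compound 2 to compound 4 (beyond the scatter), on an aromatic carbon that lies next to the ring nitrogen and next to the ring sulfur. Among these compounds, the earlier compounds offered no pair differing in one place, so this is the first reading of a single change here, and it shows that the group at this position can move the number by a large amount even when neither group carries a net charge or a hydrogen-bond donor. No measurement shown gives the cause of this drop.

One swap changes ring size and ring atoms together, so the compounds shown leave open how much each contributes, and a pyridyl ring, which keeps the six-membered ring of phenyl while adding a nitrogen, would be needed to separate the two. Also open, going by these compounds, are what an amine or a carboxylic acid would do at this same position, and whether the step keeps its size with a nitrile in place of the chlorine.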